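Swapping the Aryl Group of Compound 3

The source may hold more compounds than are shown below. What is called first, only, known or untested is meant among the compounds shown, and "the series" means these compounds.

Measured in a functional assay on SW480 cells (Homo sapiens) for antiproliferative activity; a higher number here means a weaker inhibitor, a lower number a stronger inhibitor:
- compound 1 `COc1ccc(/C=C/C(=O)c2ccc(OCCn3cc(CN4C(=O)/C=C/C(C)(C)C/C=C(\C)CC/C=C/4C)nn3)cc2O)cc1` (3.24 ug/mL)
- compound 2 `COc1cc(/C=C/C(=O)c2ccc(OCCn3cc(CN4C(=O)/C=C/C(C)(C)C/C=C(\C)CC/C=C/4C)nn3)cc2O)cc(OC)c1OC` (2.61 ug/mL)
- compound 3 `COc1ccccc1/C=C/C(=O)c1ccc(OCCCN2C(=O)/C=C/C(C)(C)C/C=C(\C)CC/C=C/2C)cc1` (1.33 ug/mL)

On these numbers, compound 3 (1.33 ug/mL) lies within the usual scatter of compound 2 (2.61 ug/mL), so those two cannot be told apart. Its number is clearly lower than that of compound 1 (3.24 ug/mL), and a lower number means a stronger inhibitor.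

The next molecule, compound 4 `C/C1=C\CC(C)(C)/C=C/C(=O)N(CCCOc2ccc(C(=O)/C=C/c3ccc(C)cc3)cc2)/C(C)=C/CC1`, differs from compound 3 in one group: 4-methylphenyl in place of 2-methoxyphenyl on a double-bonded chain carbon bound to a double-bonded chain carbon.

Among the compounds with values here, only one measured step touches this place. It is the exchange of 4-methoxyphenyl for 3,4,5-trimethoxyphenyl, which gave a 1.2-fold lower number from compound 1 to compound 2 (0.09 log units; within the scatter) and so made no clear difference. This is indirect evidence, since compound 1 and compound 2 also differ from compound 3 elsewhere in the molecule, and neither carries the group that enters here. Within the data shown here, still, the one available step suggests that this assay tolerates changes in this group, so no step beyond the scatter is expected. The expected change is a 1.2-fold higher number from compound 3 to compound 4 (0.08 log units; within the scatter) and remains only an estimate. Compound 4 is estimated at 1.6 ug/mL with an expected range from 0.7 ug/mL to 3.6 ug/mL for the measured value.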

Compound 4, half-maximal inhibitory concentration: 1.57 ug/mL
For compound 4 the middle estimate is 1.0-fold (0.01 log units) above the measured one, and the stated range covers the measured number.
By their numbers in this assay, from the lowest: compounds 3, 4, 2 and 1 (each within the scatter of the next, the first and the last beyond it).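

In this assay, replacing 2-methoxyphenyl with 4-methylphenyl on a double-bonded chain carbon bound to a double-bonded chain carbon gave a 1.2-fold higher number from compound 3 to compound 4 (0.07 log units; within the scatter) and so made no clear difference. Unlike the earlier step at this place, this one is read directly on the core of compound 3, and it takes the group from one hydrogen-bond acceptor to none, where both earlier groups kept their methoxy oxygens, so at least this exchange of an oxygen-bearing group for an all-carbon one leaves the number within the scatter. No other measurement shown bears on why the result came out this way.

The step changes the group on the ring and its printed ring position together, so a 2-methylphenyl or a 4-methoxyphenyl on the core of compound 3 would be needed to separate the two. All the aryl groups shown carry only methoxy or methyl and no net charge, which leaves open how this assay responds at this place to a phenyl ring bearing an amine or a carboxylic acid.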